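Replacing an amide arm with a urea-type arm on a pyrazole scaffold

The compounds below may be only part of what the source reports. "The series", "measured", "known", "first", "only" and "open" are said of these compounds alone.

Measured so far:
- compound 1, `O=C(Nc1cccc(-n2cc(-c3ccncc3)c(-c3ccc(Cl)c(O)c3)n2)c1)Nc1ccc(Cl)c(Cl)c1`, 9680 nM
- compound 2, `COc1cc(-c2nn(-c3cccc(NC(=O)c4cccc(C(F)(F)F)c4)c3)cc2-c2ccncc2)ccc1Cl`, only a limit
- compound 3, `O=C(Nc1cccc(-n2cc(-c3ccncc3)c(-c3ccc(Cl)c(O)c3)n2)c1)Nc1cc(C(F)(F)F)cc(C(F)(F)F)c1`, 1170 nM

In a functional assay on U-251 cells (Homo sapiens) for inhibition, read by sulforhodamine B assay, with a stated time of 48 h (a higher number here means a weaker inhibitor of growth, a lower number a stronger inhibitor of growth), compound 1 gives 9680 nM and compound 3 gives 1170 nM. For compound 2 the result is a limit rather than a number: > 50000 nM, so it sits at the limit of > 50000 nM in this assay, at which 1 of the 3 values shown sits, the weakest end of what can be read here. Compound 4, `COc1cc(-c2nn(-c3cccc(NC(=O)Nc4ccc(Cl)c(C(F)(F)F)c4)c3)cc2-c2ccncc2)ccc1Cl`, is not yet measured. It differs from compound 2 in one place: (4-chloro-3-(trifluoromethyl)phenyl)amino in place of 3-(trifluoromethyl)phenyl on a carbonyl carbon. For the measured compounds named here, no pair with exactly this change has been measured, so the size of the step can only be guessed. Since compound 2 already stands at the limit, the only resolvable direction is toward stronger inhibition, and a step beyond the scatter in that direction is expected, though it may also remain at the limit. Compound 4 is therefore estimated at 8000 nM, between 1500 nM and 40000 nM, which means an expected step of an at least 6.2-fold lower number from compound 2 to compound 4 (0.79 log units; beyond the scatter).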

Compound 4, concentration for total growth inhibition: 4180 nM
Compound 4: middle estimate off by 1.9-fold (0.28 log units), on the high side, and the stated range covers the measured number.
By their numbers in this assay, from the lowest: compound 3; then compound 4; then compound 1. At a limit, above all of these: compound 2.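

For the compounds shown here, this is the first change between two compounds that differ in one place, and it shows that this end of the molecule strongly affects growth inhibition. In this assay, replacing 3-(trifluoromethyl)phenyl on the carbonyl carbon with (4-chloro-3-(trifluoromethyl)phenyl)amino brings a compound at the limit of the read-out into the measurable range, with an at least 11-fold lower number from compound 2 to compound 4 (1.07 log units; beyond the scatter). The result for compound 2 is a limit and not a number, which leaves the full size of this step unknown: the limit of > 50000 nM in this assay, at which 1 of the 4 values shown sits.

The amino nitrogen and the chlorine enter together, and the compounds shown do not separate what each contributes to the step. As far as these compounds go, it also remains open whether a nitrile in place of that chlorine would keep the compound in the measurable range.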